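The compounds below may be only part of what the source reports. "The series", "measured", "known", "first", "only" and "open" are said of these compounds alone.

Measured in a functional assay on MCF7 cells (Homo sapiens) for cytotoxicity, read by CellTiter-Blue, with a stated time of 72 h; on this read-out lower numbers stand for stronger inhibition and higher numbers for weaker inhibition:
compound 1 `C/C=C(\C)[C@H]1OC(=O)[C@@H](C)NC(=O)[C@H]([C@@H](C)CC)NC(=O)CN(C)C(=O)[C@@H](Cc2ccccc2)N(C)C(=O)[C@@H](C)NC(=O)[C@@H](CC(C)C)OC(=O)/C(C)=C/C[C@H](O)[C@@H]1C` gives 1650 nM;
compound 2 `C/C=C(\C)[C@H]1OC(=O)[C@@H](C)NC(=O)[C@H]([C@@H](C)CC)NC(=O)CN(C)C(=O)[C@@H](Cc2ccccc2)N(C)C(=O)[C@@H](C)NC(=O)[C@@H](CC(C)C)OC(=O)/C(C)=C/C[C@H](OCSC)[C@@H]1C` gives a limit of the assay, > 10000 nM;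
compound 3 `C/C=C(\C)[C@H]1OC(=O)[C@@H](C)NC(=O)[C@H]([C@@H](C)CC)NC(=O)CN(C)C(=O)[C@@H](Cc2ccc(Cl)cc2)N(C)C(=O)[C@H](C)NC(=O)[C@@H](CC(C)C)OC(=O)/C(C)=C/C[C@H](O)[C@@H]1C` gives 0.003 nM.

Compound 3 stands far from compound 1 in this assay; the difference between the two cores is not broken down here. Within the core of compound 1, the change (methylsulfanyl)methyl in place of hydrogen on an oxygen on a saturated carbon gave an at least 6.0-fold higher number from compound 1 to compound 2 (0.78 log units; beyond the scatter), the number for compound 2 being the limit (the limit of > 10000 nM in this assay, at which 1 of the 3 values shown sits).

Compound 4 `C/C=C(\C)[C@H]1OC(=O)[C@@H](C)NC(=O)[C@H]([C@@H](C)CC)NC(=O)CN(C)C(=O)[C@@H](Cc2ccc(Cl)cc2)N(C)C(=O)[C@H](C)NC(=O)[C@@H](CC(C)C)OC(=O)/C(C)=C/C[C@H](OCSC)[C@@H]1C` carries the same change on the core of compound 3, ((methylsulfanyl)methyl in place of hydrogen on an oxygen on a saturated carbon); both changes sit at the same place, on an oxygen on a saturated carbon whose other neighbour is a saturated ring carbon. Because the step of an at least 6.0-fold higher number from compound 1 to compound 2 (0.78 log units; beyond the scatter) ran toward weaker inhibition, a loss is expected here too, estimated as a 33-fold higher number from compound 3 to compound 4 (1.52 log units; beyond the scatter). Compound 4 is expected to give about 0.1 nM, within 0.005 nM to 5 nM.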

Compound 4, half-maximal inhibitory concentration: 6.5 nM
The estimate for compound 4 lay 65-fold (1.81 log units) below the measured number; measured number outside the range, above it.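

In this assay the change from hydroxy to (methylsulfanyl)methoxy gave a 2200-fold higher number from compound 3 to compound 4 (3.34 log units; beyond the scatter), so the shift toward weaker inhibition seen on the core of compound 1 recurs on the second core: the same change on two cores in this assay, an at least 6.0-fold higher number (0.78 log units; beyond the scatter) from compound 1 to compound 2 and a 2200-fold higher number (3.34 log units; beyond the scatter) from compound 3 to compound 4; the limit leaves it open whether they differ. Compound 2 stands at a limit of the assay, > 10000 nM. From the compounds shown here alone, the direction therefore carries across these two cores, but the size of the step on the core of compound 1 is unknown, and the data do not show whether the change costs the same on both.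

Going by these compounds, whether a methyl or an acetyl group on the same oxygen would shift the number in the same way remains open. The two cores differ in more than one place, and which of those differences accounts for the gap between them also remains open.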